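Swapping Phenoxy for Dimethylamino on a Shared Pyrazole Scaffold

The source may hold more compounds than are shown below. What is called first, only, known or untested is meant among the compounds shown, and "the series" means these compounds.

Of the compounds shown here, three of one series have been tested in a functional assay on HT-29 cells (Homo sapiens) for cytotoxicity, read by sulforhodamine B assay, with a stated time of 48 h, tested at 100 nM; a lower number here means a stronger effect, a higher number a weaker effect of the compound at the concentration tested. Compound 1 `COc1cc(C)cc(-c2c(-c3ccnc(-c4ccc(C(C)=O)cc4)c3)cnn2CC#N)c1` gives 95%, and compound 2 `COc1cc(C)cc(-c2nn(CC#N)cc2-c2ccc(-c3cccc(C(C)=O)c3)nc2)c1` gives 99%. Compound 3 `Cc1cc(O)cc(-c2nn(CC#N)cc2-c2ccnc(-c3ccc(Oc4ccccc4)cc3)c2)c1` gives 91%. On the bare numbers compound 3 has the lowest figure of the three, but its distance to compound 1 and to compound 2 both lie within the usual scatter of this assay, so the three cannot be told apart: at this concentration all of them leave the cells almost untouched.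

Compound 4 `Cc1cc(O)cc(-c2nn(CC#N)cc2-c2ccnc(-c3ccc(N(C)C)cc3)c2)c1` has not yet been measured. It keeps the core of compound 3 and changes one place: dimethylamino in place of phenoxy on an aromatic carbon. Going by the values given here, no step between two already measured compounds is available as a guide, and the three measured numbers cluster in one narrow band.

From compound 3 to compound 4 the expected step in this assay is a number 2 percentage points higher from compound 3 to compound 4 (within the scatter), that is, no change beyond the scatter in either direction. Compound 4 is therefore expected to give about 93%, with a likely range from 80% to 104%.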

Compound 4, a percentage reported as activity, at one concentration (the size of the read-out at that concentration, not a potency): 102%
Compound 4: middle estimate off by 9 percentage points, on the low side; measured number inside the range.
By their numbers in this assay, from the lowest: compounds 3, 1, 2 and 4 (each within the scatter of the next, the first and the last beyond it).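

In this assay, putting dimethylamino in place of phenoxy on the aromatic carbon para to a large group gives a number 11 percentage points higher from compound 3 to compound 4 (beyond the scatter), so a higher number here means a weaker effect at the concentration tested. Going by these compounds alone, this is the first comparison in which only one place changes, and it shows that this position is not entirely silent, even though the change starts from a compound with little effect: compound 3 gives 91%. The two groups match in their counts of hydrogen-bond donors and acceptors and neither carries a net charge, but phenoxy has more heavy atoms and an aromatic ring, while dimethylamino has no ring; nothing measured here establishes which of these differences, if any, accounts for the step.

On these data alone, whether a methoxy group, which keeps the oxygen and drops the ring, or a phenyl group, which keeps the ring and drops the oxygen, would behave more like phenoxy or like dimethylamino remains open. Also open, as far as these compounds go, is how compound 3 and compound 4 compare in potency, as the read-out comes from a single concentration.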